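The source may hold more compounds than are shown below. What is called first, only, known or untested is meant among the compounds shown, and "the series" means these compounds.

Measured so far:
- compound 1 `COc1ccc(C2CC(=NOC(=O)c3ccc(Cl)cc3)CC(c3ccc(OC)cc3)N2C)cc1`: 135000 nM in a functional assay, with a stated time of 30 min; on this read-out higher numbers stand for weaker inhibition and lower numbers for stronger inhibition
- compound 2 `COc1ccc(C2CC(=NOC(=O)c3cc([N+](=O)[O-])cc([N+](=O)[O-])c3)CC(c3ccc(OC)cc3)N2C)cc1`: 312000 nM

Compound 2 stands highest of the two numbers in this assay, with compound 1 as its nearest neighbour at a 2.3-fold higher number from compound 1 to compound 2 (0.36 log units; beyond the scatter). Compound 3 `COc1ccc(C2CC(=NOC(=O)c3ccccc3O)CC(c3ccc(OC)cc3)N2C)cc1` is the next step from compound 2: 2-hydroxyphenyl in place of 3,5-dinitrophenyl on a carbonyl carbon. Within the data shown here, the only measured step touching the aryl group on the carbonyl carbon is a 2.3-fold higher number from compound 1 to compound 2 (0.36 log units; beyond the scatter), which was modest. Nothing measured speaks to a hydroxyl on that ring, so a step of similar size in either direction, or none beyond the scatter, seems plausible. Compound 3 is therefore expected near the two known values, estimated at 180000 nM (range 60000 nM to 500000 nM), a step of a 1.7-fold lower number from compound 2 to compound 3 (0.24 log units; within the scatter).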

Compound 3, half-maximal inhibitory concentration: 29000 nM
Beside the measured number, compound 3's estimate is 6.2-fold (0.79 log units) above it; measured number below the stated range.
By their numbers in this assay, from the lowest: compound 3; then compound 1; then compound 2.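

In this assay, the aryl group on the carbonyl carbon can shift the read-out much further than the earlier pair showed: 2-hydroxyphenyl gives an 11-fold lower number from compound 2 to compound 3 (1.03 log units; beyond the scatter) and a 4.7-fold lower number from compound 1 to compound 3 (0.67 log units; beyond the scatter). The change also brings in a hydrogen-bond donor, which 3,5-dinitrophenyl lacks, but this single exchange cannot separate the gain of the hydroxyl from the loss of the other ring substituents. Nothing available here explains the shift. As far as these compounds go, whether a methoxy group or an amine on that ring would match the hydroxyl remains open, as does whether the hydroxyl's place on the ring matters.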